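The source may report more compounds than this note shows. Statements on the series, on what has been measured and on what is new or still open speak of the compounds shown alone.

Compound 1 `Cc1ccc(NC(=O)CSc2nccn2-c2cccc3ccccc23)c(Br)c1` was examined in an ADME assay on MT4 cells (Homo sapiens) for cytotoxicity, read by MTT assay (a higher number here means that more compound is tolerated, a lower number that less compound is tolerated), where compound 1 gives 29400 nM, the lowest of the two numbers shown. Compound 2 `Cc1ccc(-n2ccnc2SCC(=O)Nc2ccc(C)cc2Br)cc1` gives 80800 nM in this assay, a higher number that lies beyond the scatter. Compound 3 `O=C(CSc1nccn1-c1ccc(Cl)cc1)Nc1ccccc1Br` reaches only a limit of the assay in this assay, reported as > 300000 nM. Compound 4 `O=C(CSc1nccn1-c1cccc2ccccc12)Nc1ccccc1F` has not yet been measured; it differs from compound 1 by 2-fluorophenyl in place of 2-bromo-4-methylphenyl on an amide-type nitrogen. For the measured compounds named here, no measured pair carries this change, so the step is a judgement: the expected move from compound 1 to compound 4 in this assay is a 2.0-fold higher number from compound 1 to compound 4 (0.31 log units; beyond the scatter), a modest shift toward a higher number, with a real chance that the result is only a limit because one of the three values shown already sits at the limit of > 300000 nM in this assay, at which 1 of the 3 values shown sits. Compound 4 is accordingly estimated at 60000 nM, within a range from 20000 nM to 200000 nM.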

Compound 4, half-maximal cytotoxic concentration: 34700 nM
Compound 4: the middle estimate sits 1.7-fold (0.24 log units) above what was measured; low and high end bracket the measured number.
By their numbers in this assay, from the lowest: compounds 1 and 4 (each within the scatter of the next); then compound 2. At a limit, above all of these: compound 3.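

In this assay, putting 2-fluorophenyl in place of 2-bromo-4-methylphenyl on an amide-type nitrogen, with the rest of the molecule kept, gives a 1.2-fold higher number from compound 1 to compound 4 (0.07 log units; within the scatter). This single-place comparison, the first available, shows that this exchange produces no shift distinguishable from the scatter. Compound 3 alone remains at a limit of the assay: the limit of > 300000 nM in this assay, at which 1 of the 4 values shown sits.

As far as these compounds go, whether a carboxylic acid, an amine or a longer alkyl chain in place of 2-fluorophenyl at this nitrogen would move the number stays open. So does whether the same exchange would behave alike on the core of compound 2 or compound 3.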